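This account rests on a few compounds, and the source may have more. Where it says the series, first, only, none or still open, it means among the compounds named here.

Measured compounds:
- compound 1 `Nc1ccc(-c2cc(=O)c3c(N)c(F)c(Cl)c(F)c3o2)cc1F`: 210 nM
- compound 2 `CCCCCCCCCC(=O)OCc1c(F)c(N)c2c(=O)cc(-c3ccc(N)c(F)c3)oc2c1F`: 100 nM
- compound 3 `COCc1c(F)c(N)c2c(=O)cc(-c3ccc(N)c(F)c3)oc2c1F`: 46 nM

In a functional assay on MCF7 cells (Homo sapiens) for cytotoxicity, read by neutral red uptake, with a stated time of 3 days (on this read-out lower numbers stand for stronger inhibition and higher numbers for weaker inhibition), compound 1 gives the highest number of the three, with compound 2 nearest and compound 3 furthest from it. Compound 4 `CCCCCCOCc1c(F)c(N)c2c(=O)cc(-c3ccc(N)c(F)c3)oc2c1F` differs from compound 1 by (hexyloxy)methyl in place of chloro on an aromatic carbon. Within the data shown here, two measured steps bear on this. The step of a 4.6-fold lower number from compound 1 to compound 3 (0.66 log units; beyond the scatter) shows that replacing the chloro by a methoxymethyl lowers the number. The step of a 2.2-fold lower number from compound 2 to compound 3 (0.34 log units; beyond the scatter) shows that a longer group on that oxygen gives a somewhat higher number than a methyl. A (hexyloxy)methyl is expected to sit between these cases, so a modest downward step, a 3.0-fold lower number from compound 1 to compound 4 (0.48 log units; beyond the scatter), is expected. Compound 4 is therefore estimated at 70 nM, within a range from 30 nM to 200 nM.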

Compound 4, half-maximal inhibitory concentration: 7100 nM
The estimate for compound 4 lay 100-fold (2.01 log units) below the measured number, and the stated range ends below it.
By their numbers in this assay, from the lowest: compound 3; then compound 2; then compound 1; then compound 4.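

Lengthening the ether on this aromatic carbon from methoxymethyl to (hexyloxy)methyl weakens the result sharply in this assay, with a 150-fold higher number from compound 3 to compound 4 (2.19 log units; beyond the scatter), and the longer ether also falls well behind the chloro, with a 34-fold higher number from compound 1 to compound 4 (1.53 log units; beyond the scatter). Chain size alone does not set the number, as the ester carrying the nonylcarbonyl group gives far stronger inhibition, with a 71-fold higher number from compound 2 to compound 4 (1.85 log units; beyond the scatter). No measurement shown explains this jump.

The compounds shown leave open where along the chain the number begins to climb, a gap that an ethoxymethyl or butoxymethyl group would fall into. Also open, as far as these compounds go, is how a hexyl chain ending in an amine would compare.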